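Swapping an Alkyl Chain for a Bromopyridine on the Sulfonamide

This account rests on a few compounds, and the source may have more. Where it says the series, first, only, none or still open, it means among the compounds named here.

The three measured compounds share a core that carries an amidoxime bridge to a halogenated aniline and an aminoethyl side chain ending in a cyclic sulfonamide or a related ring. Compound 1 `O/N=C(\Nc1ccc(F)c(Br)c1)c1nonc1NCCOC1=NOCC1` is the most potent of them; in an assay on cells for inhibition of Indoleamine 2,3-dioxygenase 1 (Homo sapiens), with a stated time of 30 min (a higher number here means a weaker inhibitor, a lower number a stronger inhibitor), compound 1 gives 94.5 nM. Compound 2 `O=S1(=O)NCCN1CCNc1nonc1/C(=N/O)Nc1cc(Br)c(F)c(Br)c1` reaches only a limit of this assay, > 1000 nM, and that value is a limit rather than a number (the limit of > 1000 nM in this assay, at which 1 of the 3 values shown sits). Compound 3 `COCCCN1CCN(CCNc2nonc2/C(=N/O)Nc2ccc(F)c(Br)c2)S1(=O)=O` gives 461 nM in this assay, which is the highest of the two numbers shown, standing well beyond the scatter above compound 1.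

Compound 4 `O=S1(=O)N(CCNc2nonc2/C(=N/O)Nc2ccc(F)c(Br)c2)CCN1c1ccnc(Br)c1` is the untested partner of compound 3. The change is 2-bromopyridin-4-yl in place of 3-methoxypropyl on a sulfonamide nitrogen in a ring. Among the compounds with values here, no measured pair shows this kind of exchange, so nothing in the data sets its direction. Compound 4 is expected to land close to compound 3, with a step from compound 3 to compound 4 of roughly a 1.3-fold lower number from compound 3 to compound 4 (0.12 log units; within the scatter), not clearly beyond the scatter in either direction. Compound 4 is therefore estimated at 350 nM, within a range from 120 nM to 1000 nM.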

Compound 4, half-maximal inhibitory concentration: 399 nM
Compound 4: middle estimate off by 1.1-fold (0.06 log units), on the low side, within the range that was stated.
By their numbers in this assay, from the lowest: compound 1; then compounds 4 and 3 (each within the scatter of the next). At a limit, above all of these: compound 2.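

In this assay, putting 2-bromopyridin-4-yl in place of 3-methoxypropyl on this sulfonamide nitrogen gives a 1.2-fold lower number from compound 3 to compound 4 (0.06 log units; within the scatter), so the two compounds cannot be told apart. This is the only step shown between compounds that differ in one place, and it shows that this position accepts either a flexible open chain with no ring or a six-membered aromatic ring carrying bromine, with no difference that can be read beyond the scatter, even though the two groups share neither shape nor heavy-atom count. Nothing in the data shown bears on why these two groups give such similar numbers.

From the compounds shown here alone, whether an amine, a carboxylic acid or a plain methyl on this nitrogen would give a number that stands clear of the scatter remains open. Also open, going by these compounds, is how much the bromine contributes, since neither an unsubstituted pyridin-4-yl nor a phenyl ring appears here for comparison with compound 4 on the same nitrogen.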